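Azepane in place of the anilino group on the core

The source may report more compounds than this note shows. Statements on the series, on what has been measured and on what is new or still open speak of the compounds shown alone.

Compound 1 `Cc1ccc(Cl)cc1Nc1nc(C(F)(F)F)ccc1CNC(=O)C(C)c1ccc(NS(C)(=O)=O)c(F)c1` gives 14 nM in a functional assay on CHO-K1 cells for antagonist activity at transient receptor potential cation channel subfamily V member 1 (Homo sapiens), read by FLIPR (a lower number here means a stronger inhibitor, a higher number a weaker inhibitor), the highest number of the three measured here. Within the data shown here, compound 2 `CC(C(=O)NCc1ccc(C(F)(F)F)nc1N1CCC(Cc2ccc(F)c(F)c2)CC1)c1ccc(NS(C)(=O)=O)c(F)c1` gives 0.2 nM and compound 3 `CC(C(=O)NCc1ccc(C(F)(F)F)nc1N1CCC(Cc2cc(F)cc(F)c2)CC1)c1ccc(NS(C)(=O)=O)c(F)c1` gives 0.4 nM; both lie well below compound 1, beyond the scatter, while the only measured single-point step, a 2.0-fold higher number from compound 2 to compound 3 (0.30 log units; within the scatter), concerns the difluorophenyl pattern and stays within the scatter.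

Compound 4 `CC(C(=O)NCc1ccc(C(F)(F)F)nc1N1CCCCCC1)c1ccc(NS(C)(=O)=O)c(F)c1` differs from compound 1 in one place: azepan-1-yl in place of (5-chloro-2-methylphenyl)amino on an aromatic carbon. The change sits on an aromatic carbon of a six-membered aromatic ring with one nitrogen, next to the ring nitrogen and meta to a trifluoromethyl group. Among the measured compounds shown here, no measured pair covers this exchange. What can be drawn on is that compounds 2 and 3 carry a saturated ring attached through its nitrogen at this same position and give far lower numbers than compound 1; compound 4 shares that feature but lacks the difluorophenyl-bearing chain that both of them carry.

On that basis a lower number than compound 1 is expected for compound 4, though a smaller drop than compounds 2 and 3 show. Compound 4 is thus expected to show a step of a 2.8-fold lower number from compound 1 to compound 4 (0.45 log units; beyond the scatter). Compound 4 is estimated at 5 nM, expected between 1 nM and 30 nM.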

Compound 4, inhibition constant: 0.8 nM
Compound 4: middle estimate off by 6.3-fold (0.80 log units), on the high side, and the stated range ends above it.
By their numbers in this assay, from the lowest: compounds 2, 3 and 4 (each within the scatter of the next, the first and the last beyond it); then compound 1.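

In this assay, the exchange at this aromatic carbon gives an 18-fold lower number from compound 1 to compound 4 (1.24 log units; beyond the scatter), so a low number here needs neither the carbon-only aromatic ring of the (5-chloro-2-methylphenyl)amino group nor its hydrogen-bond donor. Compounds 2 and 3 pointed towards a saturated ring attached through its nitrogen at this position, but both also carry the difluorophenyl-bearing chain, whereas the plain azepan-1-yl group of compound 4 reaches 0.8 nM, within the scatter of compound 3 at 0.4 nM. Nothing available on the series accounts for the size of this step.

Still open, from the compounds shown here alone, is whether ring size or the ring itself matters at this carbon, as a piperidin-1-yl, a pyrrolidin-1-yl or an open-chain diethylamino group would show. Also open, going by these compounds, is whether the step follows the loss of the aromatic ring or of the amino hydrogen, which a (5-chloro-2-methylphenyl)(methyl)amino group would help separate.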